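Aryl swap on the ring nitrogen: compound 1 to compound 4

The source may hold more compounds than are shown below. What is called first, only, known or untested is meant among the compounds shown, and "the series" means these compounds.

The series is read in an assay on HEK293 cells for inhibition of Voltage-dependent T-type calcium channel subunit alpha-1G (Homo sapiens), read by fluorescence, tested at 10 uM; on this read-out lower numbers stand for less inhibition and higher numbers for more inhibition at the one concentration tested (going by the name of the read-out). Compound 1 `CCCc1nc(-c2ccccc2)c(CNCCCN2CCN(c3cccc(C)c3C)CC2)o1` gives 55.2% in this assay. Compound 2 `CCCc1nc(-c2ccccc2)c(CNCCN2CCN(c3ccc(Cl)cc3)CC2)o1` gives 55.8%, and compound 3 `CCCc1nc(-c2ccccc2)c(CNCCN2CCN(c3cccc(C)c3C)CC2)o1` gives 66.7%. Compound 1 and compound 2 lie within the scatter of each other; only compound 3 stands beyond the scatter above compound 1, so compound 1 sits at the lower end of the three numbers without being separable from compound 2.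

Compound 4 `CCCc1nc(-c2ccccc2)c(CNCCCN2CCN(c3ccc(C)cc3)CC2)o1` is not yet measured. Relative to compound 1 the change is 4-methylphenyl in place of 2,3-dimethylphenyl on an amine nitrogen in a ring.

Within the data shown here, the one measured step that bears on this aryl group is a number 10.9 percentage points higher from compound 2 to compound 3 (beyond the scatter). It shows that exchanging a 4-chlorophenyl for a 2,3-dimethylphenyl raised inhibition by a modest amount on a shorter linker. The present change runs the other way, taking the 2,3-dimethylphenyl out and putting a 4-methylphenyl in, on the linker of compound 1. Among the measured compounds shown here, no step pairs 4-methylphenyl with either group, and no step tests whether this exchange behaves alike on the longer linker. A modest drop is therefore expected, possibly no more than the scatter.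

For compound 4 the expected value in this assay is 47%, within 30% to 64%. This amounts to an expected step of a number 8.2 percentage points lower from compound 1 to compound 4 (within the scatter).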

Compound 4, a percentage reported as inhibition, at one concentration (the size of the read-out at that concentration, not a potency): 53.9%
Compound 4: the middle estimate sits 6.9 percentage points below what was measured; the measured number falls inside the stated range.
By their numbers in this assay, from the lowest: compounds 4, 1 and 2 (each within the scatter of the next); then compound 3.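

In this assay, among these compounds, the exchange of 2,3-dimethylphenyl for 4-methylphenyl on the amine nitrogen in a ring gives the first aryl step on the linker of compound 1, and it reads a number 1.3 percentage points lower from compound 1 to compound 4 (within the scatter). Among the compounds shown here, on this linker the two aryl groups therefore cannot be told apart, even with one carbon fewer in the entering group, whereas the only earlier aryl step, a number 10.9 percentage points higher from compound 2 to compound 3 (beyond the scatter), separated 2,3-dimethylphenyl from 4-chlorophenyl on the shorter linker. No available data explain why this position responds as it does in the two pairs.

Still open, from the compounds shown here alone, is whether 2,3-dimethylphenyl keeps any gain over other aryl groups on the linker of compound 1, since 4-chlorophenyl has been read only on the shorter linker, and whether compound 3, at 66.7%, would hold its number with 4-methylphenyl in place of its 2,3-dimethylphenyl. The compounds shown also leave open how an unsubstituted phenyl, a 2-methoxyphenyl or a pyridine ring on the same ring nitrogen would read in this assay.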